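Swapping Chloro for Fluoro in an Antiproliferative Series

The source may hold more compounds than are shown below. What is called first, only, known or untested is meant among the compounds shown, and "the series" means these compounds.

In a functional assay on A549 cells (Homo sapiens) for antiproliferative activity, read by MTT assay, with a stated time of 24 h (on this read-out higher numbers stand for weaker inhibition and lower numbers for stronger inhibition), compound 1 `O=C(NNc1ccc(F)cc1)c1ccc(NS(=O)(=O)c2cnc(O)nc2O)cc1` gives > 20000 nM, which is a limit of the assay and not a number. Compound 2 `Cc1ccccc1NNC(=O)c1ccccc1NS(=O)(=O)c1cnc(O)nc1O` gives > 20000 nM, again a limit. Within the data shown here, compound 3 `O=C(NNc1ccccc1Cl)c1ccccc1NS(=O)(=O)c1cnc(O)nc1O` reads 5480 nM, the only true number among the values in hand. The next compound, compound 4 `O=C(NNc1ccccc1F)c1ccccc1NS(=O)(=O)c1cnc(O)nc1O`, differs from compound 3 by one change, (fluoro in place of chloro on an aromatic carbon), fluoro in place of chloro on an aromatic carbon, ortho to a large group.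

Among the measured compounds shown here, only one measured step bears on this site: an at least 3.6-fold lower number from compound 2 to compound 3 (0.56 log units; beyond the scatter), which came with chloro in place of methyl. For the measured compounds named here, that step shows the site can respond, but no measured step involves fluoro, so the evidence is thin. Going by the values given here, since chloro is the only group here with a true number, its loss is expected to give back part of that gain, a modest move towards higher numbers. The estimated change is a 2.0-fold higher number from compound 3 to compound 4 (0.30 log units; within the scatter). Compound 4 is expected to read about 11000 nM, with an estimated range from 4500 nM to 25000 nM.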

Compound 4, half-maximal inhibitory concentration: 9610 nM
Estimate against measurement, compound 4: 1.1-fold (0.06 log units) above; the measured number falls inside the stated range.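

In this assay, fluoro in place of chloro on an aromatic carbon, ortho to a large group, gives a 1.8-fold higher number from compound 3 to compound 4 (0.24 log units; within the scatter), so at this site the two halogens read alike. Fluoro also gives an at least 2.0-fold lower number from compound 2 to compound 4 (0.31 log units; beyond the scatter), which makes it a second group, alongside chloro, that reads a true number where methyl reads only a limit. The size of that step stays open-ended, since it starts from a limit of the assay and not a number: the limit of > 20000 nM in this assay, at which 2 of the 4 values shown sit.

The compounds shown leave open whether bromo, methoxy or an amine on this carbon would read like the two halogens or like methyl. Also open, on these data alone, is whether chloro and fluoro would still read alike on other cell lines.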